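Swapping fluoro for bromo on a coumarin-type ester

The source may hold more compounds than are shown below. What is called first, only, known or untested is meant among the compounds shown, and "the series" means these compounds.

Compound 1 `CCCCCC(=O)OCc1ccc2oc(=O)c(C(=O)Oc3cccc(Br)c3)cc2c1` and compound 2 `NCc1ccc2oc(=O)c(C(=O)Oc3cccc(F)c3)cc2c1` share a core that was tested in a functional assay on HT-1080 cells (Homo sapiens), read by transwell migration, with a stated time of 24 h, tested at 1 uM; on this read-out lower numbers stand for a stronger effect and higher numbers for a weaker effect at the one concentration tested. Compound 1 gives 59.3%, while compound 2 gives 45.3%, the lower of the two numbers and so the stronger effect, by a gap beyond the usual scatter. Compound 3 `NCc1ccc2oc(=O)c(C(=O)Oc3cccc(Br)c3)cc2c1` is not yet measured; it differs from compound 2 by bromo in place of fluoro on an aromatic carbon. Among the measured compounds shown here, with no measured step for this change, the expected step from compound 2 to compound 3 is small, within the scatter, a number 2.7 percentage points higher from compound 2 to compound 3 (within the scatter). Compound 3 is therefore estimated at 48%, between 34% and 62%.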

Compound 3, a percentage reported as activity, at one concentration (the size of the read-out at that concentration, not a potency): 79.3%
Estimate against measurement, compound 3: 31.3 percentage points below, and the stated range ends below it.
By their numbers in this assay, from the lowest: compound 2; then compound 1; then compound 3.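

Replacing fluoro with bromo on this aromatic carbon gives a number 34 percentage points higher from compound 2 to compound 3 (beyond the scatter), a much weaker effect, so a single atom at this place can strongly change the result. With bromo kept in place, amino in place of (pentylcarbonyl)oxy gives a number 20 percentage points higher from compound 1 to compound 3 (beyond the scatter), so the ester side chain gives the stronger effect of the two in this bromo setting. No available measurement explains either step. Where chloro or methyl at this aromatic carbon would fall remains open. So does the effect of a carboxylic acid or a longer chain in place of the amino group.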